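Hydroxy to acetoxy on compound 1

The compounds below may be only part of what the source reports. "The series", "measured", "known", "first", "only" and "open" are said of these compounds alone.

Within the data shown here, in a functional assay on MV4-11 cells (Homo sapiens) for antiproliferative activity, read by luminescence, with a stated time of 72 h (on this read-out lower numbers stand for stronger inhibition and higher numbers for weaker inhibition), compound 1 `Oc1ccc(Cn2cnc(F)c2)c2cccnc12` gives 2200 nM, the lower of the two numbers so far, while compound 2 `Oc1ccc(Cn2cncn2)c2cccnc12` gives 5200 nM. Compound 3 `CC(=O)Oc1ccc(Cn2cnc(F)c2)c2cccnc12` differs from compound 1 by acetyl in place of hydrogen on an oxygen on an aromatic ring, hydroxy to acetoxy. Among the measured compounds shown here, the only measured step, a 2.4-fold higher number from compound 1 to compound 2 (0.37 log units; beyond the scatter), is modest and lies on the saturated chain carbon, not on the oxygen, so it gives no direct guide to this change. For the measured compounds named here, with no measured precedent, the expected step is a 1.1-fold higher number from compound 1 to compound 3 (0.06 log units; within the scatter), none beyond the scatter in this assay. Compound 3 is estimated at 2500 nM, within an expected range of 900 nM to 7000 nM.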

Compound 3, half-maximal inhibitory concentration: 2900 nM
Compound 3: middle estimate off by 1.2-fold (0.06 log units), on the low side, within the range that was stated.
By their numbers in this assay, from the lowest: compounds 1, 3 and 2 (each within the scatter of the next, the first and the last beyond it).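

On the oxygen on an aromatic ring, acetyl in place of hydrogen leaves the number in this assay within the scatter (a 1.3-fold higher number from compound 1 to compound 3 (0.12 log units; within the scatter)), so this position accepts hydroxy to acetoxy without a step that can be read as a loss. The numbers do not show whether compound 3 acts as such or as compound 1, and no measurement at hand explains the result.

Open, as far as these compounds go, is whether a methyl ether or a longer acyl chain on this oxygen, or an amine in place of the hydroxy, would give a similar number.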